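Bromo in place of cyano: working notes

The compounds below may be only part of what the source reports. "The series", "measured", "known", "first", "only" and "open" are said of these compounds alone.

Values so far in a functional assay on A-375 cells (Homo sapiens) for antiproliferative activity, read by MTT assay, with a stated time of 24 h; on this read-out higher numbers stand for weaker inhibition and lower numbers for stronger inhibition
- compound 1 `COc1cc(OC)c(-c2coc3cc(OCc4ccccc4F)ccc3c2=O)cc1OC` gives 2100 nM
- compound 2 `COc1cc(OC)c(-c2coc3cc(OCc4ccc(C#N)cc4)ccc3c2=O)cc1OC` gives 1550 nM
- compound 3 `COc1cc(OC)c(-c2coc3cc(OCc4ccccc4C#N)ccc3c2=O)cc1OC` gives 990 nM

Compound 3 sits at the low end of these three numbers, reached by a 1.6-fold lower number from compound 2 to compound 3 (0.19 log units; within the scatter) and by a 2.1-fold lower number from compound 1 to compound 3 (0.33 log units; beyond the scatter) in the measured steps. Next comes compound 4 `COc1cc(OC)c(-c2coc3cc(OCc4ccccc4Br)ccc3c2=O)cc1OC` with the change bromo in place of cyano on an aromatic carbon in which bromo replaces cyano on an aromatic carbon, ortho to a large group. For the measured compounds named here, no bromo compound has been measured, so the size of this change is not known directly. Going by the values given here, a partial return towards compound 1 is expected because a 2.1-fold lower number from compound 1 to compound 3 (0.33 log units; beyond the scatter) is the only measured step at this place. The expected step in this assay is a 1.5-fold higher number from compound 3 to compound 4 (0.18 log units; within the scatter) and points to a higher number. Compound 4 is estimated at 1500 nM with an expected range from 700 nM to 3200 nM for the coming measurement.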

Compound 4, half-maximal inhibitory concentration: 2850 nM
Beside the measured number, compound 4's estimate is 1.9-fold (0.28 log units) below it; the range from low to high includes it.
By their numbers in this assay, from the lowest: compounds 3, 2, 1 and 4 (each within the scatter of the next, the first and the last beyond it).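

In this assay bromo does not stand in for cyano at this place on the aromatic carbon (a 2.9-fold higher number from compound 3 to compound 4 (0.46 log units; beyond the scatter)). Bromo and fluoro at this place cannot be told apart (a 1.4-fold higher number from compound 1 to compound 4 (0.13 log units; within the scatter)), and neither can 2-bromophenyl and 4-cyanophenyl (a 1.8-fold higher number from compound 2 to compound 4 (0.26 log units; within the scatter)). Of the three groups shown at this place, cyano alone stands apart from both halogens, with a lower number than either.

As far as these compounds go, whether an amine or a carboxylic acid at this place would read like cyano or like the halogens stays open. Nothing at hand explains the gap between cyano and bromo.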